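The source may hold more compounds than are shown below. What is called first, only, known or untested is meant among the compounds shown, and "the series" means these compounds.

Measured so far, in an ADME assay on IMR-90 cells (Homo sapiens) for cytotoxicity, read by CellTiter-Blue, with a stated time of 46 h; a lower number here means that less compound is needed, a higher number that more compound is needed for the effect:
- compound 1 `CC1(C)CCN(S(=O)(=O)c2ccc(NC(=O)c3ccc([N+](=O)[O-])o3)cc2)CC1`: compound 1 gives > 25000 nM, which is a limit of the assay and not a number.
- compound 2 `CC(C)(C)C1CCN(S(=O)(=O)c2ccc(NC(=O)c3ccc([N+](=O)[O-])o3)cc2)CC1`: compound 2 gives > 25000 nM, again a limit of the assay.
- compound 3 `O=C(Nc1ccc(S(=O)(=O)C2CCCCC2)cc1)c1ccc([N+](=O)[O-])o1`: compound 3 gives > 25000 nM, also a limit of the assay.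

Compound 1 therefore stands nowhere in particular on the numbers shown: it sits at the limit of > 25000 nM in this assay, at which 3 of the 3 values shown sit, and the two other values shown are limits of the same kind. The three steps among the measured compounds, a step that the two limits leave unreadable from compound 1 to compound 2, a step that the two limits leave unreadable from compound 1 to compound 3 and a step that the two limits leave unreadable from compound 2 to compound 3, all vary the group on the sulfonyl sulfur and none of them has a readable size.

Compound 4 `CC1(C)CCN(S(=O)(=O)c2ccc(NC(=O)c3ccc([N+](=O)[O-])s3)cc2)CC1` differs from compound 1 in 5-nitrothiophen-2-yl in place of 5-nitrofuran-2-yl on a carbonyl carbon, on a carbonyl carbon whose other neighbour is an amide-type nitrogen. Going by the values given here, no measured step touches that part of the shared core, so nothing measured bears directly on this change; the only guidance is that every compound of the series so far sits at the limit.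

Compound 4 is therefore expected to remain at or beyond that limit, with an estimated value of 30000 nM in a range from 10000 nM to 100000 nM. The step that the limit leaves unreadable from compound 1 to compound 4 is expected to show nothing beyond the scatter, and the assay will most likely again report only a limit.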

Compound 4, half-maximal effective concentration: > 25000 nM
Compound 4: no number, only a limit; the forecaster's own chance of this, stated with the estimate: 80%; the middle value does not contradict the limit.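

In this assay compound 4 gives > 25000 nM as a limit of the assay and not a number. Compound 1 likewise gives only a limit, so the step between compound 1 and compound 4 cannot be read: the limit of > 25000 nM in this assay, at which 4 of the 4 values shown sit.

The compounds shown leave open whether 5-nitrothiophen-2-yl and 5-nitrofuran-2-yl differ at all in this read-out.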